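Amide nitrogen methylation on two chloroindole methylene oxindoles

The compounds below may be only part of what the source reports. "The series", "measured", "known", "first", "only" and "open" are said of these compounds alone.

Working notes on the series. Compound 1 `COc1cc2c(cc1C)NC(=O)/C2=C/c1c(Cl)n(C)c2cc(C)c(OC)cc12` and compound 2 `COc1cc2c(cc1C)N(C)C(=O)/C2=C/c1c(Cl)n(C)c2cc(C)c(OC)cc12` share a core; the change methyl in place of hydrogen on an amide-type nitrogen in a ring makes compound 2 from compound 1. Going by the values given here, in a functional assay on cells (Cancer cell lines, Homo sapiens) for inhibition, with a stated time of 48 h (a lower number here means a stronger inhibitor of growth, a higher number a weaker inhibitor of growth), compound 1 gives 91200 nM and compound 2 gives 60300 nM; the step of a 1.5-fold lower number from compound 1 to compound 2 (0.18 log units; within the scatter) is the only measured step in the set and lies within the scatter. Compound 3 `CN(C)c1ccc2[nH]c(Cl)c(/C=C3/C(=O)Nc4ccc(O)cc43)c2c1` carries a different core, and the difference between the two cores is not broken down here. In this assay compound 3 gives 52500 nM, which is within the scatter of both compound 1 and compound 2, so nothing separates the three measured compounds in this assay. Compound 4 `CN(C)c1ccc2[nH]c(Cl)c(/C=C3/C(=O)N(C)c4ccc(O)cc43)c2c1` has not yet been measured; it is made from compound 3 by methyl in place of hydrogen on an amide-type nitrogen in a ring, which is the same change as that from compound 1 to compound 2, at the same kind of place on both cores. Among the compounds with values here, the expected step of a 1.3-fold lower number from compound 3 to compound 4 (0.12 log units; within the scatter) in this assay is estimated from the single precedent a 1.5-fold lower number from compound 1 to compound 2 (0.18 log units; within the scatter), which stayed within the scatter, and nothing else in the set bears on it. Within the data shown here, for compound 4 the value in this assay is therefore expected to be 40000 nM, most likely between 15000 nM and 100000 nM, set a little under compound 3 because of a 1.5-fold lower number from compound 1 to compound 2 (0.18 log units; within the scatter) but with a wide range given only one precedent and the lack of any test of the change on the core of compound 3.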

Compound 4, concentration for total growth inhibition: 55000 nM
Compound 4: the middle estimate sits 1.4-fold (0.14 log units) below what was measured; measured number inside the range.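

In this assay, going by these compounds alone, methyl in place of hydrogen on an amide-type nitrogen in a ring gives a 1.0-fold higher number from compound 3 to compound 4 (0.02 log units; within the scatter), so on the core of compound 3 this change produces no step that can be told from the scatter. Set beside the earlier step, the two results cannot be told apart: the same change on two cores in this assay, a 1.5-fold lower number (0.18 log units; within the scatter) from compound 1 to compound 2 and a 1.0-fold higher number (0.02 log units; within the scatter) from compound 3 to compound 4, 1.6-fold (0.20 log units) apart, within the scatter of two such steps. This shows that the two cores agree for this one change in this one assay, but the agreement is between two steps that both lie within the scatter, so it does not show that a step of real size would carry from one core to the other, nor does it say anything about cores beyond these two.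

Still open, on these data alone, is whether anything other than methyl on that amide-type nitrogen would give a step beyond the scatter on either core, for example a longer chain such as n-butyl, or a chain ending in an amine or a carboxylic acid. Within the data shown here, also open is which of the parts that differ between the core of compound 1 and the core of compound 3 matter in this assay, as no pair here changes any of them singly.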